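The source may hold more compounds than are shown below. What is called first, only, known or untested is meant among the compounds shown, and "the series" means these compounds.

For the measured compounds named here, compound 2, with the structure `COc1ccc(-c2cc(-c3ccc(-n4cncn4)cc3)cnc2N)cn1`, is the more lipophilic of the two compounds measured so far in a physicochemical assay for lipophilicity, at pH 7.4 (a lower number here means a more polar compound, a higher number a more lipophilic compound), where compound 2 gives 2.4, though its distance to its only neighbour lies within the scatter. That neighbour is compound 1, `CNS(=O)(=O)c1ccc(-c2cnc(N)c(-c3ccc(OC)nc3)c2)cc1`, for which this assay gives 2.2. Going by the values given here, the single measured step, a number 0.20 log units higher from compound 1 to compound 2 (within the scatter), is the only comparison available, and it shows that exchanging one substituent for another at this position of the shared core moved the distribution coefficient by an amount no larger than the noise of the method.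

Compound 3 has the structure `CNC(=O)c1ccc(-c2cnc(N)c(-c3ccc(OC)nc3)c2)cc1`. It differs from compound 2 in one place: methylcarbamoyl in place of 1H-1,2,4-triazol-1-yl on an aromatic carbon. The measured step from compound 1 to compound 2 bears on this change only loosely, since neither end of it carries the methylcarbamoyl group, but it suggests that this position tolerates exchanges of small groups without a large shift in this assay. Compound 3 is therefore expected to show a step of a number 0.20 log units lower from compound 2 to compound 3 (within the scatter), a change within the scatter. The value estimated for compound 3 in this assay is 2.2, within a range from 1.8 to 2.6.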

Compound 3, distribution coefficient: 1.8
Compound 3: middle estimate off by 0.40 log units, on the high side; the range from low to high includes it.
By their numbers in this assay, from the lowest: compound 3; then compounds 1 and 2 (each within the scatter of the next).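

In this assay, the aromatic carbon para to a large group turns out not to be indifferent to what it carries: methylcarbamoyl in place of 1H-1,2,4-triazol-1-yl gives a number 0.60 log units lower from compound 2 to compound 3 (beyond the scatter), and methylcarbamoyl in place of methylsulfamoyl gives a number 0.40 log units lower from compound 1 to compound 3 (beyond the scatter). The earlier exchange had stayed within the scatter, whereas compound 3 now stands apart from both of the other compounds, and having a ring at this place does not sort the three, since compound 1 has none there and still lies within the scatter of compound 2. Nothing measured here accounts for the size of these steps.

The compounds shown leave open whether the shift belongs to the amide hydrogen, which a dimethylcarbamoyl group at the same place would address, or to the carbonyl, which an aminomethyl group would remove. They also leave open whether a longer chain on the amide nitrogen, such as ethylcarbamoyl or propylcarbamoyl, would stay near compound 3 or move back towards compounds 1 and 2.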